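This account rests on a few compounds, and the source may have more. Where it says the series, first, only, none or still open, it means among the compounds named here.

As far as these compounds go, three compounds measured, one still open. Compound 2 `CC1=C(C(=O)OC2CCCCC2)C(c2cccc(C#N)c2)C2=C(CC(C)(C)CC2=O)N1` gives 43200 nM in an assay on HEK293 cells for inhibition of neurogenic locus notch homolog protein 1 (Homo sapiens), read by a luciferase reporter and resazurin assay, with a stated time of 16 h; a lower number here means a stronger inhibitor, a higher number a weaker inhibitor. Compound 1 `CC1=C(C(=O)OC2CCCCC2)C(c2ccc3c(c2)OCCO3)C2=C(CC(C)(C)CC2=O)N1` differs from compound 2 in one place, (2,3-dihydro-1,4-benzodioxin-6-yl in place of 3-cyanophenyl on a saturated ring carbon). In this assay compound 1 gives 12300 nM; the step is a 3.5-fold lower number from compound 2 to compound 1 (0.55 log units; beyond the scatter). Compound 3 `CC1=C(C(=O)OCC2CCN(C(=O)OC(C)(C)C)CC2)C(c2cccc(C#N)c2)C2=C(CC(C)(C)CC2=O)N1` gives 220 nM in this assay, the lowest of the three numbers; the difference between its core and the core of compound 2 is not broken down here. Compound 4 `CC1=C(C(=O)OCC2CCN(C(=O)OC(C)(C)C)CC2)C(c2ccc3c(c2)OCCO3)C2=C(CC(C)(C)CC2=O)N1` has not been measured; it differs from compound 3 in one place, (2,3-dihydro-1,4-benzodioxin-6-yl in place of 3-cyanophenyl on a saturated ring carbon). The surroundings of the place are not identical: in compound 1 the saturated ring carbon is next to the ring atom that bears a cyclohexyloxycarbonyl group (9 heavy atoms), in compound 4 next to the ring atom that bears a large group, so this is the same kind of change rather than the same change. Among the measured compounds shown here, the expected step is a 3.4-fold lower number from compound 3 to compound 4 (0.53 log units; beyond the scatter) in this assay, and it rests on the single earlier instance a 3.5-fold lower number from compound 2 to compound 1 (0.55 log units; beyond the scatter); no second instance exists to show whether the step carries over to the core of compound 3. Compound 4 is therefore expected to give about 65 nM, with a range of 25 nM to 200 nM.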

Compound 4, half-maximal inhibitory concentration: 1520 nM
For compound 4 the middle estimate is 23-fold (1.37 log units) below the measured one, outside the stated range (above it).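

Replacing 3-cyanophenyl with 2,3-dihydro-1,4-benzodioxin-6-yl does not carry over from one core to the other in this series: in this assay the new step is a 6.9-fold higher number from compound 3 to compound 4 (0.84 log units; beyond the scatter), opposite in direction to the earlier one. Set side by side, the two instances differ: the same change on two cores in this assay, a 3.5-fold lower number (0.55 log units; beyond the scatter) from compound 2 to compound 1 and a 6.9-fold higher number (0.84 log units; beyond the scatter) from compound 3 to compound 4, 24-fold (1.38 log units) apart, beyond the scatter of two such steps

So, across these four compounds, the outcome of this change depends on the core, and a step measured on the core of compound 2 is a poor guide to its size or direction on the core of compound 3. Two cores give no general rule, however, and they do not show which part of the differing ester is involved or how a third core would behave.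

Open, as far as these compounds go, is whether an ester ending in a free amine or a carboxylic acid would stay close to compound 3 at 220 nM. Also open, from the compounds shown here alone, is whether a plain phenyl group would follow the same split between the two cores.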